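The source may report more compounds than this note shows. Statements on the series, on what has been measured and on what is new or still open speak of the compounds shown alone.

Working notes on the series. Compound 1 `COC(=O)c1sc2cc(-c3ccoc3)cnc2c1N` carries a furan-3-yl group on the shared core. In a functional assay on NCI-H460 cells (Homo sapiens) for inhibition, read by sulforhodamine B assay, with a stated time of 48 h (on this read-out higher numbers stand for weaker inhibition of growth and lower numbers for stronger inhibition of growth), compound 1 gives only a limit, > 120000 nM, and not a number. A second member, compound 2 `COC(=O)c1sc2cc(-c3ccc(OC)nc3)cnc2c1N`, is measured in the same way. In this assay compound 2 likewise reaches only a limit, > 37500 nM. Going by the values given here, both values shown are therefore limits (the limit of > 120000 nM in this assay, at which 1 of the 2 values shown sits, (the limit of > 37500 nM in this assay, at which 1 of the 2 values shown sits)), so compound 1 stands on no numbered scale, and no step between measured compounds can be read.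

Compound 3 `COC(=O)c1sc2cc(-c3cccc(N)c3)cnc2c1N` differs from compound 1 by 3-aminophenyl in place of furan-3-yl on an aromatic carbon. With nothing but limits on hand, no direction for this change can be drawn from the data; the expectation is for no step beyond the scatter in this assay, with the value again likely to end at a limit. Compound 3 is estimated at 70000 nM, with a range from 15000 nM to 250000 nM. The expected step is an at least 1.7-fold lower number from compound 1 to compound 3 (0.23 log units; that floor lies within the scatter).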

Compound 3, concentration for 50% growth inhibition: > 150000 nM
Compound 3 was reported as a limit; the forecaster's own chance of this, stated with the estimate: 60%; middle value at least 2.1-fold (0.33 log units) from the limit.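

In this assay compound 3 gives only a limit, > 150000 nM. Going by these compounds alone, compound 1 also stands at a limit, so no step between compound 1 and compound 3 can be read. The compounds shown leave open whether any group at this place on the shared core gives a numbered value.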